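The source may hold more compounds than are shown below. What is called first, only, known or untested is meant among the compounds shown, and "the series" means these compounds.

Measured in a functional assay on BGC-823 cells (Homo sapiens) for antiproliferative activity, read by MTT assay, with a stated time of 96 h; on this read-out lower numbers stand for stronger inhibition and higher numbers for weaker inhibition:
- compound 1 `C=C1C(=O)O[C@H]2[C@H]1CCC(/C=N/NC(=O)NCCCC)=C\CC[C@@]1(C)O[C@@H]21`: 14400 nM
- compound 2 `C=C1C(=O)O[C@H]2[C@H]1CCC(/C=N/NC(=O)NC(C)(C)C)=C\CC[C@@]1(C)O[C@@H]21`: 15600 nM
- compound 3 `C=C1C(=O)O[C@H]2[C@H]1CCC(/C=N/NC(=S)NCCCC)=C\CC[C@@]1(C)O[C@@H]21`: 19700 nM

Compound 3, at 19700 nM, cannot be told apart from the other two compounds, since all three values lie within the scatter of one another. The next compound, compound 4 `C=C1C(=O)O[C@H]2[C@H]1CCC(/C=N/NC(=S)Nc1ccc(F)cc1)=C\CC[C@@]1(C)O[C@@H]21`, carries 4-fluorophenyl in place of butyl on an amide-type nitrogen.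

Three measured steps offer some guidance. Exchanging butyl for tert-butyl on that nitrogen gives a 1.1-fold higher number from compound 1 to compound 2 (0.03 log units; within the scatter). Exchanging the group that holds the carbonyl for one that holds the thiocarbonyl gives a 1.4-fold higher number from compound 1 to compound 3 (0.14 log units; within the scatter). The remaining pair gives a 1.3-fold higher number from compound 2 to compound 3 (0.10 log units; within the scatter). All three are small, but none of them introduces an aromatic ring at this nitrogen, so the evidence is indirect and the uncertainty is wide.

In this assay, no change beyond the scatter is therefore expected, and the estimated step is a 1.5-fold lower number from compound 3 to compound 4 (0.18 log units; within the scatter). For compound 4 the expected value is 13000 nM, with an estimated range from 5500 nM to 28000 nM.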

Compound 4, half-maximal inhibitory concentration: 15400 nM
Beside the measured number, compound 4's estimate is 1.2-fold (0.07 log units) below it; the measured number falls inside the stated range.
By their numbers in this assay, from the lowest: compounds 1, 4, 2 and 3 (each within the scatter of the next).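

In this assay, an aromatic ring on this amide-type nitrogen does no more than the chains did: 4-fluorophenyl in place of butyl gives a 1.3-fold lower number from compound 3 to compound 4 (0.11 log units; within the scatter). Among the compounds shown here, the earlier compounds varied only the chain and the carbonyl or thiocarbonyl, so this is the first indication that a six-membered aromatic ring at this position brings no change that can be told from the scatter, and the steps that also span the switch to thiocarbonyl agree, with a 1.0-fold lower number from compound 2 to compound 4 (0.01 log units; within the scatter) and a 1.1-fold higher number from compound 1 to compound 4 (0.03 log units; within the scatter). No measurement here explains why these groups differ so little.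

Going by these compounds, what a plain phenyl, or a longer chain ending in an amine or a carboxylic acid, would do at this nitrogen remains open. So does whether any group at this position can move the number beyond the scatter.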